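Notes on a methylsulfonyl aryl series: chloro to trifluoromethyl

The compounds below may be only part of what the source reports. "The series", "measured", "known", "first", "only" and "open" are said of these compounds alone.

Of the compounds shown here, three with a shared core have been measured in an assay for binding affinity to Alpha-1D adrenergic receptor (Homo sapiens), read by radioligand binding; on this read-out higher numbers stand for weaker inhibition and lower numbers for stronger inhibition. Compound 1 `CS(=O)(=O)c1cc(Cl)ccc1NCC1=NCCN1` gives 871 nM. Compound 2 `CS(=O)(=O)c1ccc(Cl)cc1NCC1=NCCN1` gives 2400 nM, the second highest of the three numbers. Compound 3 `CS(=O)(=O)c1c(F)cccc1NCC1=NCCN1` gives 3470 nM, which lies within the scatter of the number for compound 2, so no order between compound 2 and compound 3 can be read. The gap between compound 2 and compound 1 lies beyond the scatter, with compound 1 at the lower number.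

Compound 4 `CS(=O)(=O)c1ccc(C(F)(F)F)cc1NCC1=NCCN1` has not yet been measured. It differs from compound 2 by trifluoromethyl in place of chloro on an aromatic carbon. Going by the values given here, no pair of measured compounds shows this change, so its effect in this assay has no precedent here; the three measured compounds differ among themselves in other ways, and none of them carries a trifluoromethyl group. The change is expected to give a step of a 1.0-fold higher number from compound 2 to compound 4 (0.02 log units; within the scatter), within the scatter and with no firm direction. Among the compounds with values here, for compound 4 in this assay the expected value is 2500 nM, with a range from 900 nM to 7000 nM; the spread is wide because the only anchor is compound 2 at 2400 nM.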

Compound 4, inhibition constant: < 15900 nM
Compound 4: a limit, no number; the forecaster's own chance of this, stated with the estimate: 5%; the middle value is on the limit's open side.
By their numbers in this assay, from the lowest: compound 1; then compounds 2 and 3 (each within the scatter of the next).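

In this assay compound 4 gives < 15900 nM, which is a limit and not a number. Going by these compounds alone, no step can therefore be read from compound 2 to compound 4. The compounds shown leave open whether trifluoromethyl in place of chloro on an aromatic carbon changes the number in this assay, and if so, in which direction and by how much.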